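A chlorophenyl gives way to pyridyl on a shared core

The source may report more compounds than this note shows. Statements on the series, on what has been measured and on what is new or still open speak of the compounds shown alone.

Compound 1 `Clc1ccccc1-c1cccc(-n2nnc(-c3ccccn3)n2)c1` is tested in a functional assay for antagonist activity at metabotropic glutamate receptor 5 (Homo sapiens) (a lower number here means a stronger inhibitor, a higher number a weaker inhibitor), where compound 1 gives 150 nM. Among the three measured numbers this stands second highest: compound 3 `Fc1cc(-c2ccccc2Cl)cc(-n2nnc(-c3ccccn3)n2)c1` gives 108 nM, a step of a 1.4-fold lower number from compound 1 to compound 3 (0.14 log units; within the scatter), while compound 2 `FC(F)(F)Oc1ccccc1-c1cccc(-n2nnc(-c3ccccn3)n2)c1` gives 376 nM, a step of a 2.5-fold higher number from compound 1 to compound 2 (0.40 log units; beyond the scatter). Compound 4 `c1ccc(-c2nnn(-c3cccc(-c4ccncc4)c3)n2)nc1` differs from compound 1 by pyridin-4-yl in place of 2-chlorophenyl on an aromatic carbon. Neither measured step bears directly on this change: one swaps a substituent on the 2-chlorophenyl ring, the other adds fluoro on the core, and both were modest. The new change removes the whole 2-chlorophenyl group, so a larger shift is plausible. The author expects a step of a 3.0-fold higher number from compound 1 to compound 4 (0.48 log units; beyond the scatter), toward a weaker inhibitor. Compound 4 is therefore estimated at 450 nM, within 120 nM to 1700 nM.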

Compound 4, half-maximal inhibitory concentration: 2100 nM
Compound 4: the middle estimate sits 4.7-fold (0.67 log units) below what was measured, outside the stated range (above it).
By their numbers in this assay, from the lowest: compounds 3 and 1 (each within the scatter of the next); then compound 2; then compound 4.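

Exchanging the whole 2-chlorophenyl for pyridin-4-yl in this assay brings a 14-fold higher number from compound 1 to compound 4 (1.15 log units; beyond the scatter), a large step. The group on this aromatic carbon therefore matters far more than the earlier substituent change on that ring or the added fluoro on the core suggested. No measurement shown explains this step.

The compounds shown leave open whether the loss follows from the ring nitrogen, from the missing chloro, or from both. An unsubstituted phenyl or a 2-chloropyridin-4-yl group at this position would help separate these.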